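The source may hold more compounds than are shown below. What is called first, only, known or untested is meant among the compounds shown, and "the series" means these compounds.

Compound 1 `Cc1ccc(Oc2cccc(CN3CCC(n4cc(C)c(=O)[nH]c4=O)CC3)c2)cc1`: > 64000 nM (a limit)
Compound 2 `Cc1cn(C2CCN(Cc3cccc(Oc4cc(F)cc(F)c4)c3)CC2)c(=O)[nH]c1=O`: > 64000 nM (a limit)

In an ADME assay on MRC5 cells (Homo sapiens) for cytotoxicity, read by fluorescence and resazurin assay, with a stated time of 3 days (on this read-out lower numbers stand for stronger inhibition and higher numbers for weaker inhibition), compound 2 gives > 64000 nM, which is a limit and not a number. Compound 3 `COc1cccc(Oc2cccc(CN3CCC(n4cc(C)c(=O)[nH]c4=O)CC3)c2)c1` differs from compound 2 as follows: 3-methoxyphenyl in place of 3,5-difluorophenyl on an oxygen on an aromatic ring. It carries 3-methoxyphenyl in place of 3,5-difluorophenyl on an oxygen on an aromatic ring. Among the compounds with values here, the one measured step that bears on this is a step that the two limits leave unreadable from compound 1 to compound 2, and its size cannot be read. Both measured compounds share one result: the limit of > 64000 nM in this assay, at which 2 of the 2 values shown sit. A similar swap at this place is therefore expected to bring no step beyond the scatter. The expected change is a number no higher from compound 2 to compound 3 (the limit leaves the size open). For compound 3 the estimate is 64000 nM, with an expected range from 30000 nM to 130000 nM.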

Compound 3, half-maximal inhibitory concentration: 25300 nM
Compound 3: middle estimate off by 2.5-fold (0.40 log units), on the high side; the measured number lies below the stated range.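

In this assay, the ring on the oxygen can change the reading: with 3-methoxyphenyl, a real number appears, and both steps lie beyond the scatter (an at least 2.5-fold lower number from compound 2 to compound 3 (0.40 log units; beyond the scatter); an at least 2.5-fold lower number from compound 1 to compound 3 (0.40 log units; beyond the scatter)). Each of these steps gives only a minimum size, since the other end of each is a limit of the assay. The step between compound 1 and compound 2 cannot be read, and both of their values are limits. As far as these compounds go, it remains open whether a larger step would appear with an ethoxy group or a dimethylamino group on this ring.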